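A few compounds are considered here, and "the series" means these few. Any claim that something is new, unique, unknown or untested is made for them only; others in the source may bear on it.

Measured compounds:
- compound 1, `CCCCCCCCCCCCCCC(COCc1ccccc1)NCC`, 6000 nM
- compound 2, `CCCCCCCCCCCCCCC(CO)NCCCCCC`, 6000 nM
- compound 3, `CCCCCCCCCCCCCCC(CO)NC(=O)CCCC(=O)O`, 24000 nM

In a functional assay on Jurkat cells (Homo sapiens) for inhibition (a lower number here means a stronger inhibitor, a higher number a weaker inhibitor), compound 1 stands level with compound 2 at the digits given, and the two together hold the lowest numbers of the three. The furthest from compound 1 is compound 3, whose number is higher. For the measured compounds named here, the only single-point step among the measured compounds is a 4.0-fold higher number from compound 2 to compound 3 (0.60 log units; beyond the scatter), the exchange of (3-carboxypropyl)carbonyl for hexyl on the amine nitrogen.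

Compound 4, `CCCCCCCCCCCCCCC(COCc1ccccc1)N(CC)CC`, differs from compound 1 by ethyl in place of hydrogen on an amine nitrogen. Going by the values given here, no measured step bears directly on this change: the one step that exists replaces an alkyl group on the nitrogen with an acyl group, not a hydrogen with a second alkyl group, and it went toward a higher number. As far as these compounds go, that compound 1 and compound 2 sit level despite different alkyl groups on the nitrogen suggests the nitrogen tolerates some variation, but a second substituent is untested. The expected step is therefore a 1.2-fold higher number from compound 1 to compound 4 (0.07 log units; within the scatter), small and uncertain in direction. Compound 4 is estimated at 7000 nM in this assay, within a range of 2500 nM to 20000 nM.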

Compound 4, half-maximal inhibitory concentration: 20000 nM
Estimate against measurement, compound 4: 2.9-fold (0.46 log units) below; the measured number falls inside the stated range.
By their numbers in this assay, from the lowest: compounds 1 and 2 (each within the scatter of the next); then compounds 4 and 3 (each within the scatter of the next).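

In this assay, ethyl in place of hydrogen on the amine nitrogen, which turns ethylamino into diethylamino, gives a 3.3-fold higher number from compound 1 to compound 4 (0.52 log units; beyond the scatter) and lies beyond the scatter, so this nitrogen does not take a second ethyl group without weakening inhibition on the core of compound 1. The earlier step on a nitrogen, a 4.0-fold higher number from compound 2 to compound 3 (0.60 log units; beyond the scatter), exchanged one substituent for another and left the hydrogen in place, whereas this step removes that hydrogen and shows that a change of this kind also registers in the read-out, with no acyl group or carboxylic acid involved. Nothing among the data offers a measured explanation for this rise.

As far as these compounds go, it remains open whether a smaller methyl group or a second hexyl group in place of the same hydrogen would give a step of similar size, or whether an acetyl group there would behave differently again. From the compounds shown here alone, it is also open whether ethyl in place of this hydrogen would have a comparable effect on a core carrying the free hydroxyl group, as compound 2 does, rather than the core of compound 1.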